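Triazene benzamides and esters against a leukemia cell line

The source may report more compounds than this note shows. Statements on the series, on what has been measured and on what is new or still open speak of the compounds shown alone.

Measured compounds:
Compound 1, `CN(C)/N=N/c1cccc(C(N)=O)c1`, gives 3.8 in a functional assay on L1210 cells (Mus musculus) for antiproliferative activity; a higher number here means a more potent compound, by a factor of ten per unit of this negative logarithm, a lower number a less potent compound.
Compound 2, `CN(C)/N=N/c1ccc(C(N)=O)cc1`, gives 3.51 in this assay.
Compound 3, `COC(=O)c1ccc(/N=N/N(C)C)cc1`, gives 3.2 in this assay.

All three carry the same dimethyltriazene group attached to a benzene ring, with a carbonyl-bearing substituent elsewhere on the ring. Compound 1 and compound 2 have the same atoms joined differently; the difference between these two cores is not broken down here. Their values lie within the usual scatter of each other, so no order between them can be read from the data.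

Between compound 2 and compound 3 the change is methoxy in place of amino on a carbonyl carbon. That change produced a step of a number 0.31 log units lower from compound 2 to compound 3 (beyond the scatter), a modest loss that nonetheless lies beyond the scatter.

Compound 4, `COC(=O)c1cccc(/N=N/N(C)C)c1`, has not yet been measured. Among the compounds with values here, it differs from compound 1 by methoxy in place of amino on a carbonyl carbon, which is the same change, at a place described in the same words, as the one that took compound 2 to compound 3. Among the compounds shown, this change occurs twice in all, and only one instance is measured, so the expectation rests on that single step. On that basis the step from compound 1 to compound 4 is expected to be about a number 0.30 log units lower from compound 1 to compound 4 (within the scatter), because the measured step was a number 0.31 log units lower from compound 2 to compound 3 (beyond the scatter). The value of compound 4 is therefore estimated at 3.5, most likely between 3.1 and 3.9, and the position of the substituent on the ring, not tested in this form before, is the main uncertainty.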

Compound 4, logarithm of the reciprocal of the active concentration, log(1/C): 3.42
The estimate for compound 4 lay 0.08 log units above the measured number; the range from low to high includes it.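

In this assay, putting methoxy in place of amino on the carbonyl carbon of compound 1 gave a step of a number 0.38 log units lower from compound 1 to compound 4 (beyond the scatter). This is the same change that was already measured on the other core, and the two steps agree in size: the same change on two cores in this assay, a number 0.31 log units lower (beyond the scatter) from compound 2 to compound 3 and a number 0.38 log units lower (beyond the scatter) from compound 1 to compound 4, 0.07 log units apart, within the scatter of two such steps. Within the data shown here, with only two cores available, this shows that the change carried over between these two, but it does not show that a step of this size would appear on any other core, and it gives no reason for the loss in potency.

The compounds shown leave open whether other groups on the same carbonyl carbon, such as the hydroxyl of a carboxylic acid, the ethoxy of an ethyl ester or a methylamino group, would follow the same trend as methoxy. They also leave open what happens when the dimethyltriazene group itself is altered, for example by replacing one of its methyl groups with a longer chain such as ethyl or propyl, and whether the carbonyl change would then give a similar step.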